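Amide for aminomethyl linker: what compound 3 might show

This account rests on a few compounds, and the source may have more. Where it says the series, first, only, none or still open, it means among the compounds named here.

Measured so far:
Compound 1 `CN(Cc1ccc(Oc2ccccc2)cc1)Cc1cn(C)c2ccc(CNc3ccc(F)cc3)cc12`: 35700 nM
Compound 2 `CN(Cc1ccc(-c2ccccc2)cc1)Cc1cn(C)c2ccc(CNc3ccc(F)cc3)cc12`: 34400 nM

In a functional assay on Jurkat cells (Homo sapiens) for antiproliferative activity, read by MTT assay, with a stated time of 72 h (a lower number here means a stronger inhibitor, a higher number a weaker inhibitor), compound 2 gives 34400 nM, and compound 1 gives 35700 nM; these two numbers lie within the usual scatter of each other, so neither can be called the stronger inhibitor. Among the measured compounds shown here, the one measured step, a 1.0-fold lower number from compound 1 to compound 2 (0.02 log units; within the scatter), concerns the phenyl-versus-phenoxy end of the molecule and not the part changed next.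

Compound 3 `CN(Cc1ccc(-c2ccccc2)cc1)Cc1cn(C)c2ccc(C(=O)Nc3ccc(F)cc3)cc12` differs from compound 2 in a different place: (4-fluorophenyl)carbamoyl in place of ((4-fluorophenyl)amino)methyl on an aromatic carbon. For the measured compounds named here, no measured step touches this linker, so there is no direct guide to the size or direction of the change. In the absence of such a guide, the number for compound 3 is expected to stay near that of compound 2, with the step of a 1.1-fold lower number from compound 2 to compound 3 (0.06 log units; within the scatter) estimated to fall within the scatter. Compound 3 is therefore estimated at 30000 nM in this assay, with a range from 10000 nM to 90000 nM.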

Compound 3, half-maximal inhibitory concentration: > 100000 nM
Compound 3: no number, only a limit; the forecaster's own chance of this, stated with the estimate: 15%; at least 3.3-fold (0.52 log units) between middle value and limit.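

Replacing ((4-fluorophenyl)amino)methyl with (4-fluorophenyl)carbamoyl on this aromatic carbon gives an at least 2.9-fold higher number from compound 2 to compound 3 (0.46 log units; beyond the scatter), whereas the phenyl-for-phenoxy change gave only a 1.0-fold lower number from compound 1 to compound 2 (0.02 log units; within the scatter). Compound 3 has no exact number in this assay, only a limit, > 100000 nM. The linker is thus the first place in this small set where a single change weakens the compound measurably, but the full size of that loss cannot be read from a limit: the limit of > 100000 nM in this assay, at which 1 of the 3 values shown sits.

As far as these compounds go, what drives the loss remains open, as no property of either linker is given as measured here. It is also unknown whether a sulfonamide or an ether linker on the same carbon would stay close to compound 2 or weaken the compound as the carbamoyl group does in compound 3.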